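This account rests on a few compounds, and the source may have more. Where it says the series, first, only, none or still open, it means among the compounds named here.

Measured compounds in a functional assay on isolated protein for inhibition of Glucose-dependent insulinotropic receptor (Rattus norvegicus), read by HTRF and cAMP accumulation; on this read-out higher numbers stand for larger maximal responses and lower numbers for smaller maximal responses:
- compound 1, `Cc1nc(S(C)(=O)=O)ccc1Oc1ncnc(OC2CCN(C(=O)OC(C)(C)C(F)(F)F)CC2)c1F`, gives 79%
- compound 2, `Cc1nc(S(C)(=O)=O)ccc1Oc1ncnc(OC2CCN(C(=O)O[C@@H](C)CF)CC2)c1F`, gives 84%
- compound 3, `Cc1nc(S(C)(=O)=O)ccc1Oc1ncnc(OC2CCN(C(=O)SC3CC3)CC2)c1F`, gives 80%

Compound 2 holds the highest of the three numbers, but compound 3 and compound 1 both lie within the scatter of it, so no order among the three can be read from these values. The three steps between them are all small: a number 5 percentage points higher from compound 1 to compound 2 (within the scatter), a number 1 percentage points higher from compound 1 to compound 3 (within the scatter) and a number 4 percentage points lower from compound 2 to compound 3 (within the scatter). Each of them exchanges one group on the carbonyl carbon of the shared core, and none moves the maximal response beyond the scatter.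

Compound 4, `Cc1nc(S(C)(=O)=O)ccc1Oc1ncnc(OC2CCN(C(=S)OC3(C)CC3)CC2)c1F`, is not yet measured. Relative to compound 2 the change is a group of 7 heavy atoms (5 carbon, 1 oxygen, 1 sulfur; one three-membered non-aromatic ring of carbon only) in place of a group of 7 heavy atoms (4 carbon, 2 oxygen, 1 fluorine; no ring), on an amine nitrogen in a ring. The measured steps bear on it insofar as they also vary the group carried by the amine nitrogen in the ring, and all three were within the scatter. Going by the values given here, no measured pair, however, covers an exchange of the whole group including the double bond, so the new group is only partly covered. The expectation is therefore no step beyond the scatter, a number 4 percentage points lower from compound 2 to compound 4 (within the scatter). Compound 4 is estimated to give 80% in this assay, with a range from 68% to 92%.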

Compound 4, largest response reached (reported as efficacy), in percent of the reference or control that the assay uses: 49%
Compound 4: the middle estimate sits 31 percentage points above what was measured; measured number outside the range, below it.
By their numbers in this assay, from the lowest: compound 4; then compounds 1, 3 and 2 (each within the scatter of the next).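

In this assay the group on the amine nitrogen in a ring is no longer a position of flat response: the exchange to the group of compound 4 gives a number 35 percentage points lower from compound 2 to compound 4 (beyond the scatter), a number 31 percentage points lower from compound 3 to compound 4 (beyond the scatter) and a number 30 percentage points lower from compound 1 to compound 4 (beyond the scatter), whereas every earlier exchange stayed within the scatter. Compound 3 also carries sulfur and a three-membered non-aromatic ring of carbon only in this group and stays within the scatter of compound 1 and compound 2, so these two features together do not suffice for the drop; in compound 4 the sulfur sits in the double bond, oxygen takes the other place on that carbon, and the ring bears a methyl group. Nothing available explains the lower maximal response.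

The compounds shown do not separate the carbon-sulfur double bond from the methyl group on the ring, since compound 3 and compound 4 differ in both. Also open, as far as these compounds go, is whether the drop persists when the double-bonded sulfur is paired with a simple ethyl chain, or when an amine nitrogen replaces the oxygen on that carbon.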